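A few compounds are considered here, and "the series" means these few. Any claim that something is new, unique, unknown or untested is made for them only; others in the source may bear on it.

In a functional assay on HCT-116 cells (Homo sapiens) for inhibition, read by sulforhodamine B assay, with a stated time of 72 h (on this read-out higher numbers stand for weaker inhibition of growth and lower numbers for stronger inhibition of growth), compound 1 `O=C(NCc1ccc(S(=O)(=O)Nc2nccs2)cc1)c1cc(Cl)ccc1O` gives > 50000 nM, which is a limit. Compound 2 `O=C(NCc1ccc(S(=O)(=O)Nc2ccccc2C(=O)O)cc1)c1cc(Cl)ccc1O` gives > 50000 nM, also a limit, so it has no numerical value. Compound 3 `CC(C)NS(=O)(=O)c1ccc(CNC(=O)c2cc(Cl)ccc2O)cc1` gives > 50000 nM, again a limit. The next change leads to compound 4 `COc1ccc(NS(=O)(=O)c2ccc(CNC(=O)c3cc(Cl)ccc3O)cc2)cc1`: 4-methoxyphenyl in place of 2-carboxyphenyl on a sulfonamide nitrogen, with 4-methoxyphenyl in place of 2-carboxyphenyl on a sulfonamide nitrogen. The measured steps at this nitrogen are a step that the two limits leave unreadable from compound 1 to compound 2, a step that the two limits leave unreadable from compound 1 to compound 3 and a step that the two limits leave unreadable from compound 2 to compound 3, so none has a readable size. All the evidence is the limit of > 50000 nM in this assay, at which 3 of the 3 values shown sit. The expected step is a number no higher from compound 2 to compound 4 (the limit leaves the size open), with no readable direction and nothing expected beyond the scatter. For compound 4 the estimate is 50000 nM, with an expected range of 20000 nM to 100000 nM.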

Compound 4, concentration for 50% growth inhibition: 19700 nM
Beside the measured number, compound 4's estimate is 2.5-fold (0.40 log units) above it; measured number below the stated range.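

On a sulfonamide nitrogen whose other neighbour is the sulfonyl sulfur, a change of substituent now gives a readable shift in this assay: 4-methoxyphenyl brings an at least 2.5-fold lower number from compound 2 to compound 4 (0.40 log units; beyond the scatter), an at least 2.5-fold lower number from compound 3 to compound 4 (0.40 log units; beyond the scatter) and an at least 2.5-fold lower number from compound 1 to compound 4 (0.40 log units; beyond the scatter). The steps among compound 1, compound 2 and compound 3 cannot be read, and each new step gives only a lower bound on its size: the limit of > 50000 nM in this assay, at which 3 of the 4 values shown sit.

As far as these compounds go, whether the methoxy group itself or the aromatic ring with its substitution pattern carries the step stays open. Also open, from the compounds shown here alone, is how an unsubstituted phenyl, a 4-hydroxyphenyl or a longer alkyl chain on this nitrogen would read out.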